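Removing a Pentyl Chain from a Selenium Atom

The source may report more compounds than this note shows. Statements on the series, on what has been measured and on what is new or still open speak of the compounds shown alone.

Compound 1 `CCCCC[Se]c1nc(NCc2ccc(SC)cc2)c2ccccc2n1` and compound 2 `CSc1ccc(CNc2nc([SeH])nc3ccccc23)cc1` share one core, while compound 3 `CCCCC[Se]c1nc(NCc2ccccc2)c2ccccc2n1` and compound 4 `[SeH]c1nc(NCc2ccccc2)c2ccccc2n1` share another. How the two cores differ is hydrogen in place of methylsulfanyl on an aromatic carbon. In an ADME assay on BEAS-2B cells (Homo sapiens) for cytotoxicity, read by MTT assay, with a stated time of 72 h (a higher number here means a weaker inhibitor of growth, a lower number a stronger inhibitor of growth), compound 1 gives 88200 nM, and compound 2 gives 58200 nM. The change between these two is hydrogen in place of pentyl on a selenium, and it produced a 1.5-fold lower number from compound 1 to compound 2 (0.18 log units; within the scatter). For compound 3 the assay reports only a limit, > 100000 nM. The step of an at least 1.1-fold higher number from compound 1 to compound 3 (0.05 log units; that floor lies within the scatter) therefore rests on that limit, (the limit of > 100000 nM in this assay, at which 1 of the 3 values shown sits), and says little about the methylsulfanyl group. The change from compound 3 to compound 4 is hydrogen in place of pentyl on a selenium, the same change as from compound 1 to compound 2, now made on the core without the methylsulfanyl group. Because the earlier step was a 1.5-fold lower number from compound 1 to compound 2 (0.18 log units; within the scatter), a small step is expected again, and the expected step is an at least 1.1-fold lower number from compound 3 to compound 4 (0.04 log units; that floor lies within the scatter). For compound 4 the estimate in this assay is 90000 nM, expected to fall between 45000 nM and 200000 nM. A new limit rather than a number is also a real possibility.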

Compound 4, concentration for total growth inhibition: > 100000 nM
Compound 4 was reported as a limit (the forecaster's own chance of this, stated with the estimate: 45%); at least 1.1-fold (0.04 log units) between middle value and limit.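

Compound 4 is reported in this assay only as a limit, > 100000 nM. Compound 3 also stands at a limit, so the step between these two compounds, hydrogen in place of pentyl on a selenium, cannot be read.

With hydrogen on the selenium, putting hydrogen in place of methylsulfanyl on an aromatic carbon gives an at least 1.7-fold higher number from compound 2 to compound 4 (0.23 log units; that floor lies within the scatter). This step and its counterpart on the pentyl core are both only floors, so they show no sign that the change behaves differently on the two cores, yet they do not show that it behaves alike: the same change on two cores in this assay, an at least 1.1-fold higher number (0.05 log units; that floor lies within the scatter) from compound 1 to compound 3 and an at least 1.7-fold higher number (0.23 log units; that floor lies within the scatter) from compound 2 to compound 4; the limit leaves it open whether they differ. Any reading of this change is held back by how often the same limit appears: the limit of > 100000 nM in this assay, at which 2 of the 4 values shown sit.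

Left open is whether the methylsulfanyl group or the pentyl chain has any real effect in this assay on either core. Also open, as far as these compounds go, is how a longer chain on the selenium, or an amine in place of the methylsulfanyl group, would read there.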